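This account rests on a few compounds, and the source may have more. Where it says the series, first, only, none or still open, it means among the compounds named here.

In an assay on HEK293 cells for negative allosteric modulation of metabotropic glutamate receptor 5 (Homo sapiens), read by FLIPR, with a stated time of 1 h (a higher number here means a weaker inhibitor, a lower number a stronger inhibitor), compound 1 `C(#Cc1nc2c(s1)CN(C1CCCCC1)CC2)c1ccccc1` gives only a limit, > 10000 nM. Compound 2 `O=C(C1CCCC1)N1CCc2nc(C#Cc3ccccc3)sc2C1` likewise gives only a limit, > 10000 nM. The step that the two limits leave unreadable from compound 1 to compound 2 therefore cannot be read. Compound 2 stands at the limit of > 10000 nM in this assay, at which 2 of the 2 values shown sit. Compound 3 `O=C(C1CCCCC1)N1CCc2nc(C#Cc3ccccc3)sc2C1` differs from compound 2 by cyclohexyl in place of cyclopentyl on a carbonyl carbon. Within the data shown here, no measured step bears on this change, since both values shown are limits, so no step beyond the scatter is expected in this assay in either direction, and compound 3 is expected to stay at the limit. The expected step is a step that the limit leaves unreadable from compound 2 to compound 3. Compound 3 is estimated at 20000 nM, between 5000 nM and 100000 nM.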

Compound 3, half-maximal inhibitory concentration: > 10000 nM
Compound 3 was reported as a limit; the forecaster's own chance of this, stated with the estimate: 80%; the middle value is on the limit's open side.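

In this assay no step can be read among compound 1, compound 2 and compound 3, each value being a limit: the limit of > 10000 nM in this assay, at which 3 of the 3 values shown sit. The compounds shown leave open how far each lies past that limit, and whether cyclopentyl or cyclohexyl on a carbonyl carbon makes any difference.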